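Ethoxy Out, Ethyl and Methyl In on the Triazole Aryl

The source may hold more compounds than are shown below. What is called first, only, known or untested is meant among the compounds shown, and "the series" means these compounds.

Three compounds have been measured in a functional assay on MCF7 cells (Homo sapiens) for antiproliferative activity, read by MTT assay, with a stated time of 48 h; on this read-out higher numbers stand for weaker inhibition and lower numbers for stronger inhibition:
compound 1 `CCc1ccccc1-n1nncc1CN1C(=O)C2(C(C#N)=C(N)Oc3c(N)cc4nc5ccccc5nc4c32)c2ccccc21` — 24600 nM
compound 2 `CC(=O)Nc1ccc(-n2nncc2CN2C(=O)C3(C(C#N)=C(N)Oc4c(N)cc5nc6ccccc6nc5c43)c3ccccc32)cc1` — > 50000 nM
compound 3 `CCOc1ccccc1-n1nncc1CN1C(=O)C2(C(C#N)=C(N)Oc3c(N)cc4nc5ccccc5nc4c32)c2ccccc21` — > 50000 nM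

Compound 3 stands at the edge of what this assay reports: for compound 3 the result is > 50000 nM, a limit of the assay and not a number. Compound 2 also returns only a limit, > 50000 nM. Compound 1 alone gives a number, 24600 nM.

Compound 4 `CCc1cccc(C)c1-n1nncc1CN1C(=O)C2(C(C#N)=C(N)Oc3c(N)cc4nc5ccccc5nc4c32)c2ccccc21`, not yet measured, differs from compound 3 by 2-ethyl-6-methylphenyl in place of 2-ethoxyphenyl on an aromatic nitrogen. The step that bears on this most directly is an at least 2.0-fold higher number from compound 1 to compound 3 (0.30 log units; that floor lies within the scatter), which ran the opposite way, ethoxy replacing ethyl. The steps of an at least 2.0-fold higher number from compound 1 to compound 2 (0.30 log units; that floor lies within the scatter) and a step that the two limits leave unreadable from compound 2 to compound 3 concern other aryl groups and say little here. Because of the limit of > 50000 nM in this assay, at which 2 of the 3 values shown sit, none of these steps has a readable size beyond its floor.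

Restoring ethyl in compound 4 is expected to bring the number back toward that of compound 1, whose value 24600 nM is the only numerical anchor. Among the measured compounds shown here, the added methyl has no measured counterpart. Compound 4 is therefore estimated at 30000 nM, with a range from 10000 nM to 100000 nM. The expected step of an at least 1.6-fold lower number from compound 3 to compound 4 (0.22 log units; that floor lies within the scatter) cannot be sized sharply, since compound 3 itself is a limit.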

Compound 4, half-maximal inhibitory concentration: > 50000 nM
Compound 4 was reported as a limit (the forecaster's own chance of this, stated with the estimate: 40%); middle value at least 1.6-fold (0.22 log units) from the limit.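

In this assay compound 4 returns > 50000 nM, which is a limit of the assay and not a number. Methyl in place of hydrogen on the aromatic carbon gives an at least 2.0-fold higher number from compound 1 to compound 4 (0.30 log units; that floor lies within the scatter), so the ethyl group that compound 4 shares with compound 1 does not, in the presence of this added methyl, bring back a readable value, and compound 1 remains the only compound here with a number. The 2-ethyl-6-methylphenyl group carries no oxygen and no hydrogen-bond acceptor, unlike the 2-ethoxyphenyl group it replaces, yet the steps to compound 4 from compound 2 and from compound 3 cannot be read, because both ends of each are limits: the limit of > 50000 nM in this assay, at which 3 of the 4 values shown sit.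

From the compounds shown here alone, what remains open is the size of any difference among compound 2, compound 3 and compound 4, and whether the added methyl truly weakens the result, since the printed floor does not lie beyond the scatter. Also open, going by these compounds, is how this aryl position would respond to a fluorine, a chlorine, an amine or a carboxylic acid on the ring in place of the ethyl group.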